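A Methoxy Step Repeated on a Second Core

A few compounds are considered here, and "the series" means these few. Any claim that something is new, unique, unknown or untested is made for them only; others in the source may bear on it.

Compound 1, `COc1ccc(Cn2c(SCc3cc([N+](=O)[O-])cc([N+](=O)[O-])c3)nnc2-c2ccccc2)cc1`, in an ADME assay on HepG2 cells (Homo sapiens) for cytotoxicity, with a stated time of 48 h (on this read-out higher numbers stand for weaker inhibition and lower numbers for stronger inhibition), gives > 30000 nM, which is a limit of the assay rather than a number.
Compound 2, `O=[N+]([O-])c1cc(CSc2nnc(-c3ccccc3)n2Cc2ccccc2)cc([N+](=O)[O-])c1`, in this assay gives > 30000 nM, again a limit and not a number.
Compound 3, `Cn1c(SCc2ccccc2)nnc1-c1cc([N+](=O)[O-])cc([N+](=O)[O-])c1`, in this assay gives > 30000 nM, also a limit.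

The change from compound 2 to compound 1 is methoxy in place of hydrogen on an aromatic carbon. The step it made, a step that the two limits leave unreadable from compound 2 to compound 1, has no readable size since the limit of > 30000 nM in this assay, at which 3 of the 3 values shown sit, holds both of its ends. Compound 4, `COc1ccc(CSc2nnc(-c3cc([N+](=O)[O-])cc([N+](=O)[O-])c3)n2C)cc1`, has not yet been measured. It differs from compound 3 by methoxy in place of hydrogen on an aromatic carbon, the same change as in the measured pair, made at a place described in the same words. How the core of compound 3 differs from the core of compound 2 is not broken down here. For compound 4 the expected step is a step that the limit leaves unreadable from compound 3 to compound 4, an estimate resting on the measured pair, whose step that the two limits leave unreadable from compound 2 to compound 1 left both ends at the limit. Compound 4 is estimated at 40000 nM, with the expectation that only a limit will be reported.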

Compound 4, half-maximal inhibitory concentration: > 30000 nM
Compound 4 was reported as a limit (the forecaster's own chance of this, stated with the estimate: 85%); the middle value is on the limit's open side.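

Compound 3 and compound 4 are both reported only as limits of the assay and not as numbers, so no new step can be read between them: the limit of > 30000 nM in this assay, at which 4 of the 4 values shown sit.

The compounds shown leave open whether methoxy in place of hydrogen changes anything in this assay and how far any of the four compounds lies from that limit.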